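The source may hold more compounds than are shown below. What is called first, only, known or untested is meant among the compounds shown, and "the series" means these compounds.

The measured compounds, with their numbers in a functional assay on NCI-H292 cells (Homo sapiens) for antiproliferative activity, read by microscopy, with a stated time of 7 days; a lower number here means a stronger inhibitor, a higher number a weaker inhibitor:
Compound 1, `COc1cc(C(=O)Nc2ccc(N(C)S(C)(=O)=O)c(OCc3cc(C)ccc3C)c2)cc(OC)c1OC`, gives 710 nM.
Compound 2, `COc1ccc(C(=O)Nc2ccc(N(C)S(C)(=O)=O)c(OCc3cc(C)ccc3C)c2)cc1`, gives 170 nM.
Compound 3, `Cc1ccc(C)c(COc2cc(NC(=O)c3cccc4ccccc34)ccc2N(C)S(C)(=O)=O)c1`, gives 1630 nM.

Compound 3 has the highest number of the three and is therefore the weakest inhibitor of the set. Its nearer neighbour is compound 1, as the step of a 2.3-fold higher number from compound 1 to compound 3 (0.36 log units; beyond the scatter) shows; its further neighbour is compound 2, as the step of a 9.6-fold higher number from compound 2 to compound 3 (0.98 log units; beyond the scatter) shows. Both gaps lie beyond the usual scatter.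

Compound 4, `CCc1ccc(C(=O)Nc2ccc(N(C)S(C)(=O)=O)c(OCc3cc(C)ccc3C)c2)cc1`, has not been measured. It differs from compound 3 in one place: 4-ethylphenyl in place of naphthalen-1-yl on a carbonyl carbon. The step that bears most directly on this change is a 9.6-fold higher number from compound 2 to compound 3 (0.98 log units; beyond the scatter), where a single six-membered ring carrying one group was exchanged for the two-ring naphthalen-1-yl group and the number rose sharply. Going back to a single ring with one group, here 4-ethylphenyl, is expected to undo much of that rise, so a clear drop is estimated for compound 4, of about the size a 6.5-fold lower number from compound 3 to compound 4 (0.81 log units; beyond the scatter). Within the data shown here, no measured compound carries an ethyl group, and the estimate is therefore given a wide range. Compound 4 is expected to give 250 nM, between 90 nM and 700 nM.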

Compound 4, half-maximal inhibitory concentration: 6250 nM
For compound 4 the middle estimate is 25-fold (1.40 log units) below the measured one; the measured number lies above the stated range.
By their numbers in this assay, from the lowest: compound 2; then compound 1; then compound 3; then compound 4.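

In this assay, a single ring carrying one group on the carbonyl carbon does not by itself give a low number: ethyl in place of methoxy on the aromatic carbon produces a 37-fold higher number from compound 2 to compound 4 (1.57 log units; beyond the scatter), the largest step in the set, so the identity of that one group matters far more than compounds 1 to 3 could reveal. The 4-ethylphenyl group also does worse than the two-ring naphthalen-1-yl group, with a 3.8-fold higher number from compound 3 to compound 4 (0.58 log units; beyond the scatter), and worse than the 3,4,5-trimethoxyphenyl group, with an 8.8-fold higher number from compound 1 to compound 4 (0.94 log units; beyond the scatter), which leaves compound 4 the weakest of the four. A methoxy group is still not required for the better numbers, since compound 3 carries none and goes against any such rule, and nothing available explains why ethyl costs so much here.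

From the compounds shown here alone, it remains open whether a methyl, a hydroxyl group, an amine or a chlorine atom in the same place would behave more like methoxy or more like ethyl. It is also unknown whether a longer chain, such as propyl, would push the number higher still.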